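Branching the methoxyalkyl chain on the amine nitrogen

The source may hold more compounds than are shown below. What is called first, only, known or untested is meant among the compounds shown, and "the series" means these compounds.

Measured so far in a functional assay on MV4-11 cells (Homo sapiens) for antiproliferative activity, read by CellTiter-Glo, with a stated time of 72 h (a higher number here means a weaker inhibitor of growth, a lower number a stronger inhibitor of growth), for the series
- compound 1 `COCCN[C@H]1CC[C@H](Nc2cc(-c3csc(NCC4CCOCC4)n3)c(Cl)cn2)CC1` gives 170 nM
- compound 2 `COCCCN[C@H]1CC[C@H](Nc2cc(-c3csc(NCC4CCOCC4)n3)c(Cl)cn2)CC1` gives 1090 nM

For the measured compounds named here, compound 2 holds the higher of the two numbers, and compound 1 is its only measured neighbour. Compound 3 `COC[C@H](C)N[C@H]1CC[C@H](Nc2cc(-c3csc(NCC4CCOCC4)n3)c(Cl)cn2)CC1` rearranges the same atoms on the amine nitrogen: 1-(methoxymethyl)ethyl in place of 3-methoxypropyl on an amine nitrogen is the change, 1-(methoxymethyl)ethyl in place of 3-methoxypropyl, with a defined stereocentre added. Going by the values given here, only one measured step bears on it: a 6.4-fold higher number from compound 1 to compound 2 (0.81 log units; beyond the scatter) on the same side chain. No branched chain has been measured, so that step transfers only loosely. As compound 3 gives up the 3-methoxypropyl of compound 2 at 1090 nM in this assay a downward move is expected, somewhat smaller than the measured rise. The estimated step is a 3.6-fold lower number from compound 2 to compound 3 (0.56 log units; beyond the scatter) overall. For compound 3 the expected value is 300 nM within an estimated range of 90 nM to 900 nM for this measurement.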

Compound 3, concentration for 50% growth inhibition: 440 nM
The estimate for compound 3 lay 1.5-fold (0.17 log units) below the measured number, and the stated range covers the measured number.
By their numbers in this assay, from the lowest: compound 1; then compound 3; then compound 2.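

Working notes: in this assay, the arrangement of the chain on this amine nitrogen matters and not only its atoms, since 1-(methoxymethyl)ethyl and 3-methoxypropyl hold the same heavy atoms and yet the rearrangement gives a 2.5-fold lower number from compound 2 to compound 3 (0.39 log units; beyond the scatter) with the branched chain. Set against the 2-methoxyethyl chain of compound 1, the added methyl on the chain carbon bound to the amine nitrogen still costs activity, with a 2.6-fold higher number from compound 1 to compound 3 (0.41 log units; beyond the scatter) and compound 1 keeping the lowest number of the three. No supporting data are available to explain either step.

How much of the branched chain's number depends on its defined stereocentre remains open, as the opposite configuration is not among the compounds shown. Also open, going by these compounds, is how a hydroxyl in place of the methoxy, or an oxetane ring on the amine nitrogen, would compare.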